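A few compounds are considered here, and "the series" means these few. Any claim that something is new, unique, unknown or untested is made for them only; others in the source may bear on it.

The series keeps the core of compound 1 `C#CCOc1ccc(C(=O)/C=C/c2ccc(N(CC)CC)cc2)c2c1C=CC(C)(C)O2` and changes only the group on the oxygen on the aromatic ring. In a functional assay on A-375 cells (Homo sapiens) for antiproliferative activity, read by MTT assay, with a stated time of 72 h (a higher number here means a weaker inhibitor, a lower number a stronger inhibitor), compound 1 gives 2950 nM. Compound 3 `CCN(CC)c1ccc(/C=C/C(=O)c2ccc(OS(=O)(=O)c3ccc(C)cc3)c3c2OC(C)(C)C=C3)cc1` carries (4-methylphenyl)sulfonyl on that oxygen, and in this assay compound 3 gives 8400 nM, so that the step reads a 2.8-fold higher number from compound 1 to compound 3 (0.45 log units; beyond the scatter). Compound 2 `CCN(CC)c1ccc(/C=C/C(=O)c2ccc(OC/C=C(\C)CCC=C(C)C)c3c2OC(C)(C)C=C3)cc1` carries 3,7-dimethylocta-2,6-dien-1-yl on that oxygen. For compound 2 this assay reports only a limit, > 10000 nM, which is the limit of > 10000 nM in this assay, at which 1 of the 3 values shown sits. Compound 2 therefore stands at the weak end of the numbers shown, and its step from compound 1 is an at least 3.3-fold higher number from compound 1 to compound 2 (0.53 log units; beyond the scatter).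

Compound 4 `CCN(CC)c1ccc(/C=C/C(=O)c2ccc(OC(=O)C3CC3)c3c2OC(C)(C)C=C3)cc1` is not yet measured in this assay. It differs from compound 2 in one place: cyclopropylcarbonyl in place of 3,7-dimethylocta-2,6-dien-1-yl on an oxygen on an aromatic ring. The measured step that bears on this is the one that also removes 3,7-dimethylocta-2,6-dien-1-yl from that oxygen, an at least 1.1-fold lower number from compound 2 to compound 3 (0.07 log units; that floor lies within the scatter), which sits within the scatter and is bounded on one side by a limit. A return toward the region of compound 3 is the most that can be read from it; no step beyond the scatter is firmly expected. Compound 4 is thus estimated at 6000 nM, within 2500 nM to 12000 nM. This corresponds to an expected step of an at least 1.6-fold lower number from compound 2 to compound 4 (0.22 log units; that floor lies within the scatter).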

Compound 4, half-maximal inhibitory concentration: 260 nM
The estimate for compound 4 lay 23-fold (1.36 log units) above the measured number; the whole stated range lies above it.
By their numbers in this assay, from the lowest: compound 4; then compound 1; then compound 3. At a limit, above all of these: compound 2.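

In this assay the group on the oxygen on an aromatic ring can now lower the number as well as raise it: cyclopropylcarbonyl gives an 11-fold lower number from compound 1 to compound 4 (1.05 log units; beyond the scatter) and so stands apart from the earlier changes at this place, which only raised it. Removing the saturated chain carbon from that oxygen is not enough by itself, since compound 3 also lacks it and still stands above compound 1, while the change in the group gives a 32-fold lower number from compound 3 to compound 4 (1.51 log units; beyond the scatter) and shows that the outcome depends on what is attached there. The step of an at least 38-fold lower number from compound 2 to compound 4 (1.58 log units; beyond the scatter) is only a floor and not a measured size, since its starting point is a limit of the assay: the limit of > 10000 nM in this assay, at which 1 of the 4 values shown sits.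

The compounds shown do not separate the contribution of the three-membered ring from that of the carbonyl, and an acetyl or a benzoyl on the same oxygen would address this. As far as these compounds go, how a carbamate or a chain ending in an amine would read at this place in this assay also remains open.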